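Bromine for ester on the amide-linked phenyl ring

This account rests on a few compounds, and the source may have more. Where it says the series, first, only, none or still open, it means among the compounds named here.

Measured compounds and their values:
- compound 1, `COC(=O)c1ccc(NC(=O)C2(C(=O)Nc3ccc(Nc4ncc5cc(C(=O)N(C)C)n(C6CCCC6)c5n4)cc3)CC2)cc1`: 92%
- compound 2, `CN(C)C(=O)c1cc2cnc(Nc3ccc(NC(=O)C4(C(=O)Nc5cccc(F)c5)CC4)cc3)nc2n1C1CCCC1`: 91.8%
- compound 3, `CN(C)C(=O)c1cc2cnc(Nc3ccc(NC(=O)C4(C(=O)Nc5ccccc5F)CC4)cc3)nc2n1C1CCCC1`: 88.6%

In a functional assay on A549 cells (Homo sapiens) for inhibition, read by CCK-8 assay, with a stated time of 72 h, tested at 10 uM (on this read-out higher numbers stand for more inhibition of growth at the one concentration tested and lower numbers for less inhibition of growth), compound 1 gives 92%, the largest of the three numbers, although its steps to the other two compounds lie within the scatter. The step from compound 1 to compound 2 is a number 0.2 percentage points lower from compound 1 to compound 2 (within the scatter), the step from compound 1 to compound 3 is a number 3.4 percentage points lower from compound 1 to compound 3 (within the scatter), and between compound 2 and compound 3 there is a number 3.2 percentage points lower from compound 2 to compound 3 (within the scatter). All three share one core and differ only in the aryl group on an amide-type nitrogen.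

Compound 4, `CN(C)C(=O)c1cc2cnc(Nc3ccc(NC(=O)C4(C(=O)Nc5cccc(Br)c5)CC4)cc3)nc2n1C1CCCC1`, has not yet been measured. It differs from compound 1 by 3-bromophenyl in place of 4-(methoxycarbonyl)phenyl on an amide-type nitrogen. For the measured compounds named here, the step that bears on this most directly is the one from compound 1 to compound 2, in which a 3-fluorophenyl took the same place with a change of a number 0.2 percentage points lower from compound 1 to compound 2 (within the scatter). On that basis no step beyond the scatter is expected in this assay for compound 4, in either direction. The step from compound 1 to compound 4 is therefore estimated as a number 1 percentage points lower from compound 1 to compound 4 (within the scatter). Compound 4 is expected to give about 91%, most likely between 83% and 97%.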

Compound 4, percent growth inhibition at one concentration: 92.2%
Beside the measured number, compound 4's estimate is 1.2 percentage points below it, within the range that was stated.
By their numbers in this assay, from the lowest: compounds 3, 2, 1 and 4 (each within the scatter of the next).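

In this assay the change to 3-bromophenyl on the amide-type nitrogen gives a number 0.2 percentage points higher from compound 1 to compound 4 (within the scatter), which shows that this place takes a group with 7 heavy atoms and 0 hydrogen-bond acceptors as well as 4-(methoxycarbonyl)phenyl with 10 heavy atoms and 2 hydrogen-bond acceptors, with no step beyond the scatter. The halogen matters as little here: bromo in place of fluoro on an aromatic carbon gives a number 0.4 percentage points higher from compound 2 to compound 4 (within the scatter), and 3-bromophenyl in place of 2-fluorophenyl gives a number 3.6 percentage points higher from compound 3 to compound 4 (within the scatter), so all the aryl groups shown at this place fall within the scatter of one another. Nothing available explains why these different aryl groups read alike.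

The compounds shown leave open whether a carboxylic acid or an amine on the phenyl ring, or a cyclohexyl group in place of that ring, would read the same at this place. They also leave open whether these compounds, alike at the one concentration tested, would separate at lower concentrations.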